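Methyl in place of trifluoromethyl: notes on compound 3

The source may hold more compounds than are shown below. What is called first, only, known or untested is meant among the compounds shown, and "the series" means these compounds.

Within the data shown here, compound 1 `FC(F)(F)c1ccccc1NC(=S)N/N=C/c1ccc2ccccc2n1` is the only member of the set with a measured number: in a functional assay on HT-29 cells (Homo sapiens) for antiproliferative activity, read by sulforhodamine B assay, with a stated time of 72 h (on this read-out higher numbers stand for weaker inhibition and lower numbers for stronger inhibition), compound 1 gives 18100 nM. Compound 2 `NC(=S)N/N=C/c1cc2cccnc2s1` carries a different core and reaches only the edge of the assay. In this assay compound 2 gives > 100000 nM, which is a limit and not a number (the limit of > 100000 nM in this assay, at which 1 of the 2 values shown sits). Between compound 1 and compound 2 no step in a single place is defined, so their two values are taken only as they stand, one a number and one a limit.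

Compound 3 `Cc1ccccc1NC(=S)N/N=C/c1ccc2ccccc2n1` is not yet measured. The change from compound 1 to compound 3 is methyl in place of trifluoromethyl on an aromatic carbon. Among the measured compounds shown here, no measured pair in the set differs in this one place, so the size of the step rests on no precedent. The step from compound 1 to compound 3 is expected to be a 1.1-fold higher number from compound 1 to compound 3 (0.04 log units; within the scatter), that is, none beyond the usual scatter in either direction. On that basis compound 3 is expected to give 20000 nM in this assay, with a range from 7000 nM to 60000 nM. A result reported only as a limit is considered unlikely for compound 3.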

Compound 3, half-maximal inhibitory concentration: 42300 nM
Compound 3: middle estimate off by 2.1-fold (0.33 log units), on the low side, within the range that was stated.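

The series now has its first measured step in a single place: on an aromatic carbon ortho to a large group, methyl in place of trifluoromethyl gives a 2.3-fold higher number from compound 1 to compound 3 (0.37 log units; beyond the scatter) in this assay and so marks a modest change beyond the usual scatter. This shows that the read-out responds to this exchange at this place, which the earlier pair could not show, as compound 1 and compound 2 differ in more than one place and compound 2 is reported only as a limit. Compound 3 also gives a number rather than a limit, so the step can be read directly, but nothing shown bears on why it has this size.

As far as these compounds go, it remains open whether a chlorine atom, a methoxy group or an amine at this same carbon would give a number close to that of compound 1, close to that of compound 3 or outside both. A single step also leaves open whether methyl in place of trifluoromethyl would give a similar change elsewhere on this ring or on another core.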